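The source may report more compounds than this note shows. Statements on the series, on what has been measured and on what is new or still open speak of the compounds shown alone.

Series measured in a functional assay on MCF7 cells (Homo sapiens) for inhibition, read by CCK-8 assay, with a stated time of 48 h; on this read-out lower numbers stand for stronger inhibition and higher numbers for weaker inhibition:
- compound 1 `COc1cc(-c2ccnc3cc(-c4c[nH]c5ccccc45)nn23)cc(OC)c1OC` gives 85 nM
- compound 2 `COc1cc(-c2ccnc3cc(-c4ccc(Cl)cc4)nn23)cc(OC)c1OC` gives 2320 nM
- compound 3 `COc1cc(-c2ccnc3cc(-c4ccc(C)cc4)nn23)cc(OC)c1OC` gives 47 nM

Compound 3 stands at the low end of these numbers. It cannot be separated from compound 1 (a 1.8-fold lower number from compound 1 to compound 3 (0.26 log units; within the scatter)) but lies far from compound 2 (a 49-fold lower number from compound 2 to compound 3 (1.69 log units; beyond the scatter)).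

The next analogue is compound 4 `COc1cc(-c2ccnc3cc(-c4ccc(C)c(C)c4)nn23)cc(OC)c1OC`, with methyl in place of hydrogen on an aromatic carbon, ortho to a methyl group and meta to a large group: 4-methylphenyl to 3,4-dimethylphenyl (methyl in place of hydrogen on an aromatic carbon).

For the measured compounds named here, no measured step makes this exact change. The closest evidence is the swap of chloro for methyl (a 49-fold lower number from compound 2 to compound 3 (1.69 log units; beyond the scatter)), which shows that a single substituent on this ring can produce a large step. The replacement of 1H-indol-3-yl (a 1.8-fold lower number from compound 1 to compound 3 (0.26 log units; within the scatter)) shows that a larger group can leave the number within the scatter. Together these allow a step in either direction, but a modest move to a higher number seems likeliest in this assay.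

The expected step is a 2.1-fold higher number from compound 3 to compound 4 (0.33 log units; beyond the scatter).

For compound 4 the estimated value is 100 nM, within an expected range of 30 nM to 500 nM.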

Compound 4, half-maximal inhibitory concentration: 26 nM
Estimate against measurement, compound 4: 3.8-fold (0.59 log units) above, and the stated range ends above it.
By their numbers in this assay, from the lowest: compounds 4, 3 and 1 (each within the scatter of the next, the first and the last beyond it); then compound 2.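

In this assay, methyl in place of hydrogen on the aromatic carbon ortho to a methyl group and meta to a large group gives no readable change (a 1.8-fold lower number from compound 3 to compound 4 (0.26 log units; within the scatter)), so this position accepts a second methyl group on the ring at this level of resolution. The 3,4-dimethylphenyl group stays far from the 4-chlorophenyl group (an 89-fold lower number from compound 2 to compound 4 (1.95 log units; beyond the scatter)) and, unlike the 4-methylphenyl group, separates beyond the scatter from the 1H-indol-3-yl group, though only modestly (a 3.3-fold lower number from compound 1 to compound 4 (0.51 log units; beyond the scatter)). No available measurement bears on the origin of these differences.

Open, from the compounds shown here alone, is whether this position accepts anything other than methyl, such as an ethyl group, an amine or a carboxylic acid. Also open, going by these compounds, is whether the added methyl would hold up with chloro in place of the existing methyl group.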